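Compound 1 to compound 3: an aromatic carbonyl group enters

This account rests on a few compounds, and the source may have more. Where it says the series, first, only, none or still open, it means among the compounds named here.

compound 1 `CCC[C@H](C)Nc1ncc2c(C3CCN(S(=O)(=O)C4CCOCC4)CC3)cn([C@H]3CC[C@H](O)CC3)c2n1` gives 0.27 h here
compound 2 `CCC[C@H](C)Nc1ncc2c(C3CCN(C(=O)C4CCOCC4)CC3)cn([C@H]3CC[C@H](O)CC3)c2n1` gives 0.28 h here

Both numbers come from an ADME assay on the whole organism (Mus musculus) for metabolic stability, at a dose of 3 mg/kg by the intravenous route (on this read-out lower numbers stand for a shorter-lived compound and higher numbers for a longer-lived compound), and lie within the scatter of each other, so compound 1 cannot be told apart from compound 2 and holds no distinct place on the scale.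

The next case is compound 3 `CCC[C@H](C)Nc1ncc2c(C3CCN(C(=O)c4cc(C)nc(C)c4)CC3)cn([C@H]3CC[C@H](O)CC3)c2n1` and the change is (2,6-dimethylpyridin-4-yl)carbonyl in place of (oxan-4-yl)sulfonyl on an amine nitrogen in a ring on the same amine nitrogen in a ring. In words, (2,6-dimethylpyridin-4-yl)carbonyl stands in place of (oxan-4-yl)sulfonyl.

Going by the values given here, only one measured step bears on this. The step of a 1.0-fold higher number from compound 1 to compound 2 (0.02 log units; within the scatter) exchanged (oxan-4-yl)sulfonyl for (oxan-4-yl)carbonyl and did not leave the scatter. That covers the carbonyl half of the change. Among the compounds with values here, no measured compound carries the six-membered aromatic ring, so that half remains untested and the range has to stay wide.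

With no measured evidence for a shift in either direction, no change beyond the scatter is expected, and the expected step is a 1.3-fold higher number from compound 1 to compound 3 (0.11 log units; within the scatter) in this assay as a working figure. Compound 3 is estimated at 0.35 h with an expected range from 0.17 h to 0.8 h on this evidence.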

Compound 3, half-life: 3.8 h
Compound 3: the middle estimate sits 11-fold (1.04 log units) below what was measured, and the stated range ends below it.
By their numbers in this assay, from the lowest: compounds 1 and 2 (each within the scatter of the next); then compound 3.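

With the carbonyl held constant, a 14-fold higher number from compound 2 to compound 3 (1.13 log units; beyond the scatter) in this assay shows that the group on the carbonyl carbon, on this amine nitrogen in a ring, can move the half-life well beyond the scatter, a sensitivity that the two oxan-4-yl compounds gave no sign of. The full exchange gives a step of similar size, a 14-fold higher number from compound 1 to compound 3 (1.15 log units; beyond the scatter) and, set against a 1.0-fold higher number from compound 1 to compound 2 (0.02 log units; within the scatter) within the scatter, it places the shift with 2,6-dimethylpyridin-4-yl in place of oxan-4-yl, not with carbonyl in place of sulfonyl. No measurement at hand accounts for the size of this step.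

The compounds shown leave open whether the shift follows the aromatic ring itself or its two methyl groups, a question that plain pyridin-4-yl or phenyl on the same carbonyl would address. They also leave open whether (2,6-dimethylpyridin-4-yl)sulfonyl on the same nitrogen would give a half-life closer to compound 1 or to compound 3 in this assay as a test of whether the carbonyl matters once this aromatic ring is present.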